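This account rests on a few compounds, and the source may have more. Where it says the series, first, only, none or still open, it means among the compounds named here.

In a functional assay on HeLa cells (Homo sapiens) for cytotoxicity, read by MTT assay (on this read-out lower numbers stand for stronger inhibition and higher numbers for weaker inhibition), compound 1 (`CC(C)=CC[C@@H](OC(=O)CCO)C1=CC(=O)c2c(O)ccc(O)c2C1=O`) gives 67600 nM, compound 2 (`CCCC(O)CC(=O)O[C@H](CC=C(C)C)C1=CC(=O)c2c(O)ccc(O)c2C1=O`) gives 59300 nM and compound 3 (`CC(C)=CC[C@@H](OC[C@@H](C)O)C1=CC(=O)c2c(O)ccc(O)c2C1=O`) gives 22500 nM. Compound 2 stands in the upper pair of these three numbers. Within that pair the gap is only a 1.1-fold lower number from compound 1 to compound 2 (0.06 log units; within the scatter), whereas leaving out the carbonyl gives a 2.6-fold lower number from compound 2 to compound 3 (0.42 log units; beyond the scatter). Compound 4 (`CC(=O)OCCC(=O)O[C@H](CC=C(C)C)C1=CC(=O)c2c(O)ccc(O)c2C1=O`) differs from compound 2 as follows: acetoxymethyl in place of 1-hydroxybutyl on a saturated chain carbon bound to a carbonyl carbon. Among the compounds with values here, the carbonyl stays, so the closest precedent is the small change within the upper pair, and the step to the 2-hydroxypropyl compound bears less directly. No step beyond the scatter is therefore expected in this assay. The estimate for compound 4 is 50000 nM, with an expected range of 20000 nM to 90000 nM. The expected change is a 1.2-fold lower number from compound 2 to compound 4 (0.07 log units; within the scatter).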

Compound 4, half-maximal inhibitory concentration: 17300 nM
Compound 4: middle estimate off by 2.9-fold (0.46 log units), on the high side, outside the stated range (below it).
By their numbers in this assay, from the lowest: compounds 4 and 3 (each within the scatter of the next); then compounds 2 and 1 (each within the scatter of the next).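

In this assay keeping the carbonyl does not hold a compound in the upper pair: on the saturated chain carbon bound to a carbonyl carbon, acetoxymethyl in place of 1-hydroxybutyl gives a 3.4-fold lower number from compound 2 to compound 4 (0.54 log units; beyond the scatter) and acetyl in place of hydrogen on the oxygen gives a 3.9-fold lower number from compound 1 to compound 4 (0.59 log units; beyond the scatter) as well. The ester compound also reaches the level of the carbonyl-free one, with a 1.3-fold lower number from compound 3 to compound 4 (0.11 log units; within the scatter) on the same read-out. Nothing available explains this shift. Going by these compounds, whether a longer acyl chain in place of acetyl would act alike remains open, as does the outcome with an amine or a carboxylic acid at this place.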